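The source may hold more compounds than are shown below. What is called first, only, known or untested is meant among the compounds shown, and "the series" means these compounds.

Three measured compounds share one core and differ only in the ring attached to the amide carbonyl. Compound 1 `COc1cc(N(C)CCN(C)C)c(NC(=O)c2ccnc(Cl)c2)cc1Nc1nccc(-c2cn(C)c3ccccc23)n1` gives 970 nM in a functional assay on A549 cells (Homo sapiens) for antiproliferative activity, read by MTT assay, with a stated time of 72 h (a lower number here means a stronger inhibitor, a higher number a weaker inhibitor), compound 2 `COc1cc(N(C)CCN(C)C)c(NC(=O)c2cccnc2)cc1Nc1nccc(-c2cn(C)c3ccccc23)n1` gives 1600 nM in this assay, and compound 3 `COc1cc(N(C)CCN(C)C)c(NC(=O)c2cnccn2)cc1Nc1nccc(-c2cn(C)c3ccccc23)n1` gives 4330 nM in this assay. The step of a 1.6-fold higher number from compound 1 to compound 2 (0.22 log units; within the scatter) keeps compound 1 and compound 2 within the scatter of each other, whereas a 4.5-fold higher number from compound 1 to compound 3 (0.65 log units; beyond the scatter) and a 2.7-fold higher number from compound 2 to compound 3 (0.43 log units; beyond the scatter) set compound 3 beyond it, so compound 1 stands clear of compound 3 only.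

Compound 4 `COc1cc(N(C)CCN(C)C)c(NC(=O)c2ccnc(Cl)c2)cc1Nc1nccc(-c2cn(CCCO)c3ccccc23)n1` has not yet been measured. It differs from compound 1 in one place: 2-hydroxyethyl in place of hydrogen on a saturated chain carbon bound to an aromatic nitrogen. Among the measured compounds shown here, all three measured steps concern the ring on the carbonyl carbon, and none touches the chain carbon bound to the aromatic nitrogen, so no measured step bears on this change. With nothing to point either way, no step beyond the scatter is expected in this assay. The expected step is no change at the digits printed from compound 1 to compound 4 (within the scatter) in that assay. Compound 4 is therefore estimated at 970 nM, with a range from 400 nM to 2400 nM, in this assay.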

Compound 4, half-maximal inhibitory concentration: 2140 nM
Estimate against measurement, compound 4: 2.2-fold (0.34 log units) below, within the range that was stated.
By their numbers in this assay, from the lowest: compounds 1, 2 and 4 (each within the scatter of the next, the first and the last beyond it); then compound 3.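

Among the compounds shown here, this is the first change away from the ring on the carbonyl carbon. Going from methyl to 3-hydroxypropyl on the aromatic nitrogen, with everything else held as it is in compound 1, gives in this assay a 2.2-fold higher number from compound 1 to compound 4 (0.34 log units; beyond the scatter), so this position does respond to the change, though only modestly, and compound 4 remains a measurable inhibitor. No measurement given here explains this weakening.

As far as these compounds go, it remains open whether the step comes from the longer chain or from the hydroxyl at its end, which a plain propyl chain would help to separate, and whether an amine or a carboxylic acid at the chain end would give a different result. From the compounds shown here alone, it is also open whether the same step would appear with pyridin-3-yl or pyrazin-2-yl on the carbonyl carbon.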